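A few compounds are considered here, and "the series" means these few. Any claim that something is new, unique, unknown or untested is made for them only; others in the source may bear on it.

Compound 1 `C=C1CC[C@H]2C(C)(C)CCC[C@]2(C)[C@H]1C/C=C(\CC(=O)OCC)C(=O)O`: in a functional assay on RAW264.7 cells (Mus musculus) for inhibition, with a stated time of 24 h (on this read-out higher numbers stand for weaker inhibition and lower numbers for stronger inhibition), compound 1 reaches only the assay limit, > 50000 nM.
Compound 2 `C=C1CC[C@H]2C(C)(C)CCC[C@]2(C)[C@H]1/C=C/C1=CC(=O)O[C@H]1O`: in this assay compound 2 gives 2400 nM.
Compound 3 `C=C1CC[C@H]2C(C)(C)CCC[C@]2(C)[C@H]1C/C=C1\CC(OC)OC1=O`: in this assay compound 3 gives 24600 nM.

All three share the same bicyclic core and differ only in the side chain attached to it. Compound 2 stands at the lowest of the two real numbers, and its gap to compound 3 lies beyond the usual scatter, so compound 2 is the stronger inhibitor of the two. The value for compound 1 is a limit rather than a number (the limit of > 50000 nM in this assay, at which 1 of the 3 values shown sits).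

Compound 4 `C=C1CC[C@H]2C(C)(C)CCC[C@]2(C)[C@H]1/C=C/C(=O)O` has not yet been tested. Compared with compound 2 it shows (a group of 3 heavy atoms (1 carbon, 2 oxygen; no ring) in place of a group of 7 heavy atoms (4 carbon, 3 oxygen; one five-membered non-aromatic ring with 1 hetero atom), on a double-bonded chain carbon bound to a double-bonded chain carbon). Within the data shown here, no pair of measured compounds differs in just one place, so no measured step tells how much such a change costs or gains.

The expectation is that compound 4 inhibits more weakly than compound 2, a step of an 8.3-fold higher number from compound 2 to compound 4 (0.92 log units; beyond the scatter), since the other side chains tried here, compound 3 with 24600 nM among them, all sit at higher numbers. For compound 4 the estimated result in this assay is 20000 nM, with a likely range from 5000 nM to 60000 nM.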

Compound 4, half-maximal inhibitory concentration: 23700 nM
Beside the measured number, compound 4's estimate is 1.2-fold (0.07 log units) below it; measured number inside the range.
By their numbers in this assay, from the lowest: compound 2; then compounds 4 and 3 (each within the scatter of the next). At a limit, above all of these: compound 1.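

Among these compounds, this is the first pair that differs in one place only, so the effect of a single change on this side chain can now be read directly. Putting a carboxy group in place of the group holding the five-membered non-aromatic ring, on a double-bonded chain carbon bound to a double-bonded chain carbon, gives a 9.9-fold higher number from compound 2 to compound 4 (0.99 log units; beyond the scatter) in this assay and so counts as a real loss of inhibition. The shared core with a carboxy group at this place therefore does not match compound 2, and the stronger inhibition of compound 2 depends on the larger ring-bearing group that compound 4 lacks.

Which part of that larger group matters, whether its ring, its hydroxy-bearing stereocentre or its carbonyl, stays unsettled, and no measurement shown here bears on the reason for this step. Going by these compounds, how a methyl ester or an amide in place of the carboxy group, or a longer chain carrying the carboxy group, would behave at this place also remains open.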